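An amide-nitrogen swap in a weakly cytotoxic series

The source may hold more compounds than are shown below. What is called first, only, known or untested is meant among the compounds shown, and "the series" means these compounds.

Of the compounds shown here, three sharing one core have been measured in a functional assay on SW480 cells (Homo sapiens) for cytotoxicity, read by MTT assay, with a stated time of 24 h; a higher number here means a weaker inhibitor, a lower number a stronger inhibitor. Compound 1 `C=CC1=C(C(=O)NCCCCC)C(c2ccc(Cl)c(Cl)c2)OC1` gives 27500 nM. For compound 2 `C=CC1=C(C(=O)NCc2ccc(Cl)cc2)C(c2ccc(F)cc2)OC1` only a limit is reported, > 100000 nM. For compound 3 `C=CC1=C(C(=O)NCc2ccc(Cl)cc2)C(c2ccc(OC)cc2)OC1` the result is likewise a limit, > 100000 nM. The step that the two limits leave unreadable from compound 2 to compound 3 therefore has no readable size, and the limit of > 100000 nM in this assay, at which 2 of the 3 values shown sit, marks where compound 2 and compound 3 both sit. Compound 4 `C=CC1=C(C(=O)Nc2cccc(C)c2)C(c2ccc(F)cc2)OC1` differs from compound 2 by 3-methylphenyl in place of 4-chlorobenzyl on an amide-type nitrogen. Among the measured compounds shown here, no measured step touches the amide-type nitrogen, so none bears directly on this change, and the only readable number in this assay, that of compound 1, comes from a compound that also differs elsewhere. Compound 2 stands at a limit rather than at a number, which gives no anchor for the direction of the step. Compound 4 is therefore expected to remain weak, with an estimated 80000 nM (range 20000 nM to 250000 nM). The expected step of an at least 1.2-fold lower number from compound 2 to compound 4 (0.09 log units; that floor lies within the scatter) is accordingly uncertain and likely modest.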

Compound 4, half-maximal inhibitory concentration: > 100000 nM
Compound 4 gave a limit, no number; the forecaster's own chance of this, stated with the estimate: 60%; middle value at least 1.2-fold (0.09 log units) from the limit.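

In this assay compound 4 gives > 100000 nM, a limit and not a number. Compound 2 also stands at a limit, so no step between compound 2 and compound 4 can be read: the limit of > 100000 nM in this assay, at which 3 of the 4 values shown sit.

On these data alone, whether 3-methylphenyl in place of 4-chlorobenzyl on an amide-type nitrogen changes cytotoxicity at all stays open.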